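A few compounds are considered here, and "the series" means these few. Any claim that something is new, unique, unknown or untested is made for them only; others in the source may bear on it.

Measured so far:
compound 1, `COc1ccc(CN(C(=O)CCl)c2cc(OC)c(OC)c(OC)c2)cc1O` — 84 nM
compound 2, `COc1ccc(CNc2cc(OC)c(OC)c(OC)c2)cc1F` — 39700 nM
compound 3, `COc1ccc(CNc2cc(OC)c(OC)c(OC)c2)cc1N` — 7970 nM

All three were tested in a functional assay on MGC-803 cells (Homo sapiens) for inhibition, read by MTT assay, with a stated time of 48 h; a higher number here means a weaker inhibitor, a lower number a stronger inhibitor. Compound 1 stands at the lowest number of the three; compound 3 sits nearest to it, and compound 2 furthest away, both beyond the scatter. Among the compounds with values here, compound 2 and compound 3 differ from each other only at one aromatic carbon, and that step, a 5.0-fold lower number from compound 2 to compound 3 (0.70 log units; beyond the scatter), is the only single-place step among the measured compounds. Compound 1 differs from both of them in more than one place, so their values can only be set side by side, not read as a step.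

The unmeasured compound 4, `C/C=C/C(=O)N(Cc1ccc(OC)c(O)c1)c1cc(OC)c(OC)c(OC)c1`, differs from compound 1 as follows: prop-1-en-1-yl in place of chloromethyl on a carbonyl carbon. Within the data shown here, no measured step touches the carbonyl carbon or the group on it; the one step available concerns an aromatic carbon on a different part of the molecule and therefore does not bear on this change. The expectation for compound 4 rests on compound 1 alone and must stay wide. Compound 4 is expected to give a somewhat higher number than compound 1 in this assay, estimated at 250 nM with a range from 60 nM to 1500 nM, so that the step of a 3.0-fold higher number from compound 1 to compound 4 (0.47 log units; beyond the scatter) is expected to be modest at most.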

Compound 4, half-maximal inhibitory concentration: 27 nM
Compound 4: middle estimate off by 9.3-fold (0.97 log units), on the high side; measured number outside the range, below it.
By their numbers in this assay, from the lowest: compound 4; then compound 1; then compound 3; then compound 2.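

In this assay, putting prop-1-en-1-yl in place of chloromethyl on a carbonyl carbon gives a 3.1-fold lower number from compound 1 to compound 4 (0.49 log units; beyond the scatter), a step that is modest in size but beyond the scatter. Within the data shown here, this is the first measured change at this position, and it shows that the low number of compound 1 does not depend on the chloromethyl group, as its chlorine can leave and the number still falls. The position on the carbonyl carbon therefore accepts a group made of carbon alone, slightly larger by the count of heavy atoms and carrying a double bond outside the aromatic rings, and the value stays in the same low range rather than rising as it might have done.

The two compounds do not tell whether the double bond itself matters, and a propyl group, a plain methyl, a longer chain or a chain ending in an amine on the same carbonyl carbon could each separate that question from the mere loss of chlorine. Nothing shown here explains why this change lowers the number, and no independent measurement bears on it.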